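A few compounds are considered here, and "the series" means these few. Any claim that something is new, unique, unknown or untested is made for them only; others in the source may bear on it.

Compound 1 `O=C(c1ccc(F)cc1)N1CCC(NCCSC(c2ccc(F)cc2)c2ccc(F)cc2)CC1` carries a (4-fluorophenyl)carbonyl on the ring nitrogen and a plain sulfur in its chain; in an assay on membranes from striatum (strain Sprague-Dawley) for displacement of a labelled ligand from sodium-dependent dopamine transporter (Rattus norvegicus), read by scintillation counting, with a stated time of 120 min (a lower number here means a stronger inhibitor, a higher number a weaker inhibitor), compound 1 gives 7.04 nM. Compound 3 `CC(C)(C)C(=O)N1CCC(NCCSC(c2ccc(F)cc2)c2ccc(F)cc2)CC1` differs from it by tert-butyl in place of 4-fluorophenyl on a carbonyl carbon, and in this assay compound 3 gives 352 nM, a change of a 50-fold higher number from compound 1 to compound 3 (1.70 log units; beyond the scatter). Compound 2 `O=C(c1ccc(F)cc1)N1CCC(NCC[S+]([O-])C(c2ccc(F)cc2)c2ccc(F)cc2)CC1` has the sulfur oxidised to a sulfoxide; how its core differs from that of compound 1 is not broken down here, and in this assay compound 2 gives 77.2 nM. Compound 4 `CC(C)(C)C(=O)N1CCC(NCC[S+]([O-])C(c2ccc(F)cc2)c2ccc(F)cc2)CC1` differs from compound 2 by tert-butyl in place of 4-fluorophenyl on a carbonyl carbon, the same change, at the same place, as that from compound 1 to compound 3. Because the earlier step was a 50-fold higher number from compound 1 to compound 3 (1.70 log units; beyond the scatter), a step of similar size, a 39-fold higher number from compound 2 to compound 4 (1.59 log units; beyond the scatter), is expected here. Compound 4 is therefore estimated at 3000 nM, likely between 800 nM and 12000 nM.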

Compound 4, inhibition constant: 10200 nM
The estimate for compound 4 lay 3.4-fold (0.53 log units) below the measured number; the measured number falls inside the stated range.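

Putting tert-butyl in place of 4-fluorophenyl on the carbonyl carbon again gives a much weaker inhibitor, with a 130-fold higher number from compound 2 to compound 4 (2.12 log units; beyond the scatter). The change carries over from the core of compound 1 to the core of compound 2, and the two steps cannot be told apart: the same change on two cores in this assay, a 50-fold higher number (1.70 log units; beyond the scatter) from compound 1 to compound 3 and a 130-fold higher number (2.12 log units; beyond the scatter) from compound 2 to compound 4, 2.6-fold (0.42 log units) apart, within the scatter of two such steps. Among the compounds shown here, this rests on only two pairs of compounds in one assay, so it does not show that the step would keep its size on any other core, nor does it explain why the change has this effect.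

Still open, from the compounds shown here alone, is how other groups on the carbonyl carbon, such as methyl or cyclohexyl, would compare with these two. Also open, going by these compounds, is whether the step holds with a sulfone in place of the sulfur, or with a longer chain.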